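A Third Group on the Sulfonamide Nitrogen

This account rests on a few compounds, and the source may have more. Where it says the series, first, only, none or still open, it means among the compounds named here.

Compound 1 `O=S(=O)(Nc1ncccn1)c1ccc(Nc2nncc3ccccc23)cc1`: 43 nM
Compound 2 `O=S(=O)(Nc1nccs1)c1ccc(Nc2nncc3ccccc23)cc1`: 54 nM
Compound 3 `Cc1cc(NS(=O)(=O)c2ccc(Nc3nncc4ccccc34)cc2)no1`: not yet measured

In a functional assay on K562 cells (Homo sapiens) for antiproliferative activity, read by sulforhodamine B assay, with a stated time of 72 h (a higher number here means a weaker inhibitor, a lower number a stronger inhibitor), compound 2 gives 54 nM, and it cannot be separated from compound 1 at 43 nM, since the two values lie within the scatter of each other. Compound 3 keeps the shared core and differs from compound 2 in one place, with 5-methyl-1,2-oxazol-3-yl in place of 1,3-thiazol-2-yl on a sulfonamide nitrogen. Among the measured compounds shown here, only one measured exchange at that nitrogen bears on this change, and it is a thin guide: a 1.3-fold higher number from compound 1 to compound 2 (0.10 log units; within the scatter). On that evidence, no step beyond the scatter is expected in this assay, and no direction can be favoured with confidence. The expected change is a 1.1-fold higher number from compound 2 to compound 3 (0.05 log units; within the scatter). Compound 3 is estimated at 60 nM, with an expected range of 25 nM to 150 nM.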

Compound 3, half-maximal inhibitory concentration: 23 nM
For compound 3 the middle estimate is 2.6-fold (0.42 log units) above the measured one; the whole stated range lies above it.
By their numbers in this assay, from the lowest: compounds 3, 1 and 2 (each within the scatter of the next, the first and the last beyond it).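

In this assay, among the compounds shown here, placing 5-methyl-1,2-oxazol-3-yl instead of 1,3-thiazol-2-yl on the sulfonamide nitrogen gives a 2.3-fold lower number from compound 2 to compound 3 (0.37 log units; beyond the scatter), the first step at this position to lie beyond the scatter, though only a modest one. Set against pyrimidin-2-yl, the same group gives a 1.9-fold lower number from compound 1 to compound 3 (0.27 log units; within the scatter), so compound 3 cannot be separated from compound 1, and the three groups form a narrow run in which only the two ends, compound 3 and compound 2, stand apart. No measurement at hand bears on the reason for this step.

The compounds shown leave open whether the methyl group of 5-methyl-1,2-oxazol-3-yl contributes, since the plain 1,2-oxazol-3-yl group is not among them. They also leave open whether an acetyl group on that nitrogen, with no ring attached, would keep the number in this range.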